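Swapping the Side Group on a Pyrimidine-Type Core

This account rests on a few compounds, and the source may have more. Where it says the series, first, only, none or still open, it means among the compounds named here.

Of the compounds shown here, two sharing one core have been measured in a functional assay on Jurkat cells for inhibition of nuclear factor NF-kappa-B complex (Homo sapiens); on this read-out lower numbers stand for stronger inhibition and higher numbers for weaker inhibition. Compound 1, `CCOC(=O)c1cnc(-c2ccc(C)s2)nc1NN1C(=O)C=C(C)C1=O`, gives 200 nM in this assay. Among the compounds with values here, compound 2, `CCOC(=O)c1cnc(C(=O)c2ccco2)nc1NN1C(=O)C=C(C)C1=O`, gives 700 nM, the highest of the two numbers; the only step recorded, a 3.5-fold higher number from compound 1 to compound 2 (0.54 log units; beyond the scatter), places it beyond the scatter. Compound 3, `CCOC(=O)c1cnc(CC2=CCCCC2)nc1NN1C(=O)C=C(C)C1=O`, has not yet been measured.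

Compound 3 differs from compound 2 in one place: (cyclohex-1-en-1-yl)methyl in place of (furan-2-yl)carbonyl on an aromatic carbon. Within the data shown here, the single measured step bears on this only loosely, since it concerns the same position but a different incoming group. It shows that removing the (furan-2-yl)carbonyl group and putting a ring without hydrogen-bond acceptors in its place went along with a lower number, as compound 1 gives 200 nM against compound 2. On that basis, a modest downward step, a 1.8-fold lower number from compound 2 to compound 3 (0.24 log units; within the scatter), is expected in this assay, though with wide uncertainty. Compound 3 is therefore estimated at 400 nM, with a plausible range from 120 nM to 1500 nM.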

Compound 3, half-maximal inhibitory concentration: 2000 nM
Compound 3: the middle estimate sits 5.0-fold (0.70 log units) below what was measured, and the stated range ends below it.
By their numbers in this assay, from the lowest: compound 1; then compound 2; then compound 3.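

Across the three groups tried at this position, between the two ring nitrogen atoms, the read-out in this assay spans a 10-fold higher number from compound 1 to compound 3 (1.00 log units; beyond the scatter), so this place on the shared core clearly affects inhibition. The second step, a 2.9-fold higher number from compound 2 to compound 3 (0.46 log units; beyond the scatter), adds something the first could not show: (furan-2-yl)carbonyl and (cyclohex-1-en-1-yl)methyl have the same count of heavy atoms, so that count alone does not set the number here, and a group with no hydrogen-bond acceptors can give the highest number of the three. No measurement here explains why the numbers move in this way.

On these data alone, what remains open is whether the higher number of compound 3 goes with its non-aromatic ring or with the methyl link that joins this ring to the core, as both differ from the directly attached aromatic ring of compound 1; a benzyl group, which pairs the same kind of link with an aromatic ring, would help to pull these two apart. As far as these compounds go, how an amine or a carboxylic acid would read at this position also remains open.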